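This account rests on a few compounds, and the source may have more. Where it says the series, first, only, none or still open, it means among the compounds named here.

Compound 2 `O=c1cc(CNc2nc(-c3cc4cc(Br)cc(Br)c4oc3=O)cs2)c2ccc(Cl)cc2[nH]1` was tested in a functional assay on the whole organism for inhibition, with Rattus norvegicus as the target, read by paw edema, in the formalin test, with a stated time of 2 h, at a dose of 100 mg/kg by the intraperitoneal route (on this read-out higher numbers stand for more inhibition at the one dose given (going by the name of the read-out) and lower numbers for less inhibition), and gave 13%. Compound 1 `Cc1cccc2c(CNc3nc(-c4cc5cc(Br)ccc5oc4=O)cs3)cc(=O)[nH]c12` gave in this assay a reading of 9.19%; the two readings lie within the scatter of each other, so compound 2 stands together with compound 1 at a low level, neither separated from the other. Compound 3 `O=c1cc(CNc2nc(-c3cc4cc(Br)ccc4oc3=O)cs2)c2ccc(Cl)cc2[nH]1` differs from compound 2 by hydrogen in place of bromo on an aromatic carbon. Among the measured compounds shown here, both measured readings are small, and no structural step between measured compounds is known. A step from compound 2 to compound 3 of a number 3 percentage points lower from compound 2 to compound 3 (within the scatter) is therefore expected, none beyond the scatter. Compound 3 is estimated at 10%, within a range from 2% to 20%.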

Compound 3, a percentage reported as inhibition, in the whole organism at one dose (the size of the read-out at that dose, not a potency): 9.09%
Compound 3: the middle estimate sits 0.9 percentage points above what was measured, within the range that was stated.
By their numbers in this assay, from the lowest: compounds 3, 1 and 2 (each within the scatter of the next).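

Among the compounds shown here, exchanging bromo for hydrogen on this aromatic carbon, meta to the remaining bromo group, gives a number 3.9 percentage points lower from compound 2 to compound 3 (within the scatter) in this assay and is the first step read between compounds that differ in one place. At this low level of inhibition, the reading therefore does not separate bromo from hydrogen at this position. Nothing available offers an explanation for this result.

It remains open whether an amine or a methoxy group on this carbon would give a reading beyond the scatter of these compounds.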